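Toward a carboxylic acid on the shared core

The source may report more compounds than this note shows. Statements on the series, on what has been measured and on what is new or still open speak of the compounds shown alone.

Measured compounds and their values:
- Compound 1, `COc1ccc(C(=O)NNC(=O)c2ccc3[nH]c(-c4ccc([N+](=O)[O-])o4)nc3c2)cc1OC`, 15.6 ug/mL
- Compound 2, `COc1cccc(C(=O)NNC(=O)c2ccc3[nH]c(-c4ccc([N+](=O)[O-])o4)nc3c2)c1`, 15.6 ug/mL
- Compound 3, `O=CNNC(=O)c1ccc2[nH]c(-c3ccc([N+](=O)[O-])o3)nc2c1`, 15.6 ug/mL

All three compounds were tested in a functional assay on DU-145 cells (Homo sapiens) for inhibition, read by sulforhodamine B assay, with a stated time of 48 h; on this read-out higher numbers stand for weaker inhibition of growth and lower numbers for stronger inhibition of growth. Compound 3 stands level with compound 1 and compound 2, since the step of no change at the digits printed from compound 1 to compound 3 (within the scatter) and the step of no change at the digits printed from compound 2 to compound 3 (within the scatter) both lie within the scatter, as does the step of no change at the digits printed from compound 1 to compound 2 (within the scatter) between the two methoxy-bearing compounds. The measured results therefore show no separation among these three.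

Compound 4, `O=C(O)c1ccc2[nH]c(-c3ccc([N+](=O)[O-])o3)nc2c1`, has not yet been measured. It differs from compound 3 as follows: hydroxy in place of (formylamino)amino on a carbonyl carbon. The measured steps bear on this only loosely: they show that swapping or removing the groups carried on the second carbonyl left the read-out unchanged, but none of them removed the two nitrogens themselves, which is what the change to compound 4 does. Because no change at the digits printed from compound 1 to compound 3 (within the scatter) and the other measured steps did not move the value, the expectation for compound 4 is a step of a 1.3-fold higher number from compound 3 to compound 4 (0.11 log units; within the scatter), that is, little change beyond the scatter, with some room for weaker inhibition. Compound 4 is expected to give about 20 ug/mL, within 8 ug/mL to 60 ug/mL.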

Compound 4, concentration for 50% growth inhibition: 125 ug/mL
Beside the measured number, compound 4's estimate is 6.3-fold (0.80 log units) below it, outside the stated range (above it).
By their numbers in this assay, from the lowest: compounds 1, 2 and 3 (each within the scatter of the next); then compound 4.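

In this assay, this carbonyl carbon on the aromatic carbon proves sensitive to what it carries: hydroxy in place of (formylamino)amino gives an 8.0-fold higher number from compound 3 to compound 4 (0.90 log units; beyond the scatter), toward weaker inhibition of growth. The earlier steps changed only the group on the second carbonyl, with the two nitrogens kept, and none of them moved the read-out beyond the scatter, whereas this step removes the nitrogens and the formyl group together and is the first shown to do so. No measurement available here explains the loss.

All of the (formylamino)amino group leaves in this single step, so the compounds shown cannot tell whether the nitrogens or the formyl carbonyl account for the difference. As far as these compounds go, it remains open whether a primary amide, with one nitrogen on the carbonyl, or a hydrazide with a free amino group would stay level with compound 3 or fall toward compound 4, and whether a methyl ester would read differently from the carboxylic acid.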